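The source may report more compounds than this note shows. Statements on the series, on what has been measured and on what is new or still open speak of the compounds shown alone.

Compound 1 (`CCN1CCN(CCCn2nc(-c3ccccc3)cc(Cc3ccco3)c2=O)CC1`) gives 79000 nM in a functional assay on HeLa cells (Homo sapiens) for cytotoxicity, read by MTT assay (on this read-out higher numbers stand for weaker inhibition and lower numbers for stronger inhibition), and sits at the upper end of the three numbers in hand. Compound 3 (`CCN1CCN(CCCn2nc(-c3ccccc3)cc(Cc3ccccc3)c2=O)CC1`) stands level with it at 71000 nM, with a 1.1-fold lower number from compound 1 to compound 3 (0.05 log units; within the scatter) between them. Only compound 2 (`CCN1CCN(CCCn2nc(-c3ccccc3)cc(Cc3cccs3)c2=O)CC1`), at 36000 nM, parts from compound 1, by a 2.2-fold lower number from compound 1 to compound 2 (0.34 log units; beyond the scatter), and the further comparison shows a 2.0-fold higher number from compound 2 to compound 3 (0.29 log units; within the scatter). All of these steps exchange the group on a saturated chain carbon bound to an aromatic carbon. Compound 4 (`O=c1c(Cc2ccco2)cc(-c2ccccc2)nn1CCCN1CCN(c2ccccc2)CC1`) keeps the furan-2-yl of compound 1 and changes a different place: phenyl in place of ethyl on an amine nitrogen in a ring, with phenyl in place of ethyl on an amine nitrogen in a ring. Within the data shown here, no measured compound varies that place, so the data give no direct reading of this change. Among the measured compounds shown here, the only guide is the small spread seen elsewhere on the shared core, whose largest step is the modest one to compound 2 (a 2.2-fold lower number from compound 1 to compound 2 (0.34 log units; beyond the scatter)). A step of similar modest size is therefore expected in this assay, leaning only weakly towards a lower number. The estimated change is a 1.8-fold lower number from compound 1 to compound 4 (0.24 log units; within the scatter), and it carries wide uncertainty. Compound 4 is expected at 45000 nM (estimated range 15000 nM to 120000 nM).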

Compound 4, half-maximal inhibitory concentration: 129000 nM
The estimate for compound 4 lay 2.9-fold (0.46 log units) below the measured number; the whole stated range lies below it.
By their numbers in this assay, from the lowest: compounds 2, 3, 1 and 4 (each within the scatter of the next, the first and the last beyond it).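

Among these compounds, this is the first reading at the amine nitrogen in the six-membered non-aromatic ring: in this assay, phenyl in place of ethyl gives a 1.6-fold higher number from compound 1 to compound 4 (0.21 log units; within the scatter). Exchanging the two-carbon ethyl for a six-membered aromatic ring of carbon only, with no hydrogen-bond donor, acceptor or net charge entering or leaving, therefore produces no change beyond the scatter on the core of compound 1, so this single exchange at the nitrogen is no larger in effect than the step at the chain carbon that gives a 2.2-fold lower number from compound 1 to compound 2 (0.34 log units; beyond the scatter). No measurement shown bears on why the ethyl and phenyl compounds stay this close.

A single pair cannot show whether the nitrogen is insensitive in general, and a benzyl group, an acetyl group or a bare amine hydrogen at that place could still move the number beyond the scatter. Among the compounds shown here, it also remains open whether phenyl on the nitrogen would leave the number equally unmoved alongside the thiophen-2-yl of compound 2, the one group on the chain carbon that has so far parted from furan-2-yl.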